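The source may report more compounds than this note shows. Statements on the series, on what has been measured and on what is new or still open speak of the compounds shown alone.

Of the compounds shown here, two have been measured in an assay on mitochondria (strain BALB/c) for inhibition of glycerol-3-phosphate acyltransferase 1, mitochondrial (Mus musculus), read by scintillation counting, with a stated time of 10 min (a higher number here means a weaker inhibitor, a lower number a stronger inhibitor), so far. Compound 1 `CCCCCCCCS(=O)(=O)Nc1cc(-c2ccccc2O)ccc1C(=O)O` gives 63100 nM. Compound 2 `CCCCCCCCS(=O)(=O)Nc1ccc(-c2ccccc2Cl)cc1C(=O)O` gives 14400 nM, the lower of the two numbers, and the gap from compound 1 down to compound 2 lies beyond the usual scatter. Compound 3 `CCCCCCCCS(=O)(=O)Nc1ccc(CCc2ccc(OC)cc2)cc1C(=O)O` has not yet been measured. It differs from compound 2 in one place: 2-(4-methoxyphenyl)ethyl in place of 2-chlorophenyl on an aromatic carbon. Among the compounds with values here, no step between two measured compounds shows what a change of this kind does to the number, so the expectation for compound 3 rests on the value of compound 2 alone. Compound 3 is expected to give about 22000 nM, with a likely range from 7000 nM to 70000 nM. The step of a 1.5-fold higher number from compound 2 to compound 3 (0.18 log units; within the scatter) is thus expected to be small, not clearly beyond the scatter, with the number perhaps drifting a little higher.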

Compound 3, half-maximal inhibitory concentration: 26300 nM
Estimate against measurement, compound 3: 1.2-fold (0.08 log units) below; the measured number falls inside the stated range.
By their numbers in this assay, from the lowest: compounds 2 and 3 (each within the scatter of the next); then compound 1.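

In this assay, replacing 2-chlorophenyl with 2-(4-methoxyphenyl)ethyl gives a 1.8-fold higher number from compound 2 to compound 3 (0.26 log units; within the scatter), a step that stays within the usual scatter. Within the data shown here, this is the first reading of a single change at this position, meta to a carboxy group and para to a large group: a group with more heavy atoms and a hydrogen-bond acceptor, and without chlorine, gives a number that cannot be told apart from that of the group it replaces. No measurement at hand offers an explanation for this closeness.

On these data alone, because the ring, the two-carbon link and the methoxy all change together, their separate contributions remain open. Also open, as far as these compounds go, is whether a plain 2-phenylethyl group, an amine or a carboxylic acid at this position would shift the number beyond the scatter.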